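From 3-methylphenyl to 4-isopropylphenyl on the shared core

The source may hold more compounds than are shown below. What is called first, only, known or untested is meant among the compounds shown, and "the series" means these compounds.

Compound 1 `CN1CCN(c2ccc(Nc3ncc(Cl)c(NCc4ccccc4)n3)nc2)CC1` gives > 100000 nM as a limit
Compound 2 `Cc1cccc(Nc2nc(Nc3ccc(N4CCN(C)CC4)cn3)ncc2Cl)c1` gives 15300 nM as a number

Compound 1 stands at a limit in a functional assay on Jurkat cells (Homo sapiens) for inhibition, read by CCK-8 assay, with a stated time of 48 h (on this read-out higher numbers stand for weaker inhibition of growth and lower numbers for stronger inhibition of growth), and not at a true number. For the measured compounds named here, that leaves compound 2 with the only true number so far. Compound 3 `CC(C)c1ccc(Nc2nc(Nc3ccc(N4CCN(C)CC4)cn3)ncc2Cl)cc1` brings one change, 4-isopropylphenyl in place of 3-methylphenyl on a nitrogen on an aromatic ring and so puts 4-isopropylphenyl in place of 3-methylphenyl on a nitrogen on an aromatic ring. Going by the values given here, the one measured step is an at least 6.5-fold lower number from compound 1 to compound 2 (0.81 log units; beyond the scatter) at that same place, but it replaced benzyl, so it says little about this swap. In this assay only a small move toward lower numbers is expected, not clearly beyond the scatter. The estimated step is a 1.5-fold lower number from compound 2 to compound 3 (0.18 log units; within the scatter) for this swap. Compound 3 is expected at 10000 nM with a range from 3000 nM to 40000 nM.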

Compound 3, concentration for 50% growth inhibition: 7530 nM
For compound 3 the middle estimate is 1.3-fold (0.12 log units) above the measured one, and the stated range covers the measured number.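

At this place, on a nitrogen on an aromatic ring, one substituted phenyl can differ from another: this assay shows a 2.0-fold lower number from compound 2 to compound 3 (0.31 log units; beyond the scatter). Replacing benzyl with 4-isopropylphenyl gives an at least 13-fold lower number from compound 1 to compound 3 (1.12 log units; beyond the scatter). Compound 1 stands at a limit and not at a number: the limit of > 100000 nM in this assay, at which 1 of the 3 values shown sits.

The swap from 3-methylphenyl to 4-isopropylphenyl changes both the group and its printed ring position, and the compounds shown cannot separate those two changes. From the compounds shown here alone, how a phenyl carrying an amine or a carboxylic acid would behave here also stays open.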